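Acylating the Aniline Nitrogen of an Amine Inhibitor

The compounds below may be only part of what the source reports. "The series", "measured", "known", "first", "only" and "open" are said of these compounds alone.

Compound 1: `C[C@@H](C(=O)NC1CCCCC1)[C@H]1CC[C@@H](c2ccnc3ccc(F)cc32)CC1`, 18 nM
Compound 2: `C[C@@H](CNc1ccc(Cl)cc1)[C@H]1CC[C@@H](c2ccnc3ccc(F)cc32)CC1`, 7 nM

In an assay on tissue (HeLa cells) for inhibition of Indoleamine 2,3-dioxygenase 1 (Homo sapiens), with stated times of 2 h and 18 h (on this read-out lower numbers stand for stronger inhibition and higher numbers for weaker inhibition), compound 2, `C[C@@H](CNc1ccc(Cl)cc1)[C@H]1CC[C@@H](c2ccnc3ccc(F)cc32)CC1`, gives 7 nM, the lowest of the two numbers measured. Compound 1, `C[C@@H](C(=O)NC1CCCCC1)[C@H]1CC[C@@H](c2ccnc3ccc(F)cc32)CC1`, gives 18 nM in this assay. Going by the values given here, the single measured step, a 2.6-fold lower number from compound 1 to compound 2 (0.41 log units; beyond the scatter), exchanged an amide for a simple amine. Compound 3, `C[C@@H](CNC(=O)c1ccc(Cl)cc1)[C@H]1CC[C@@H](c2ccnc3ccc(F)cc32)CC1`, brings an amide back: (4-chlorophenyl)carbonyl in place of 4-chlorophenyl on an amine nitrogen. Because a 2.6-fold lower number from compound 1 to compound 2 (0.41 log units; beyond the scatter) accompanied loss of a carbonyl, reinstating one is expected to raise the number modestly, a 2.1-fold higher number from compound 2 to compound 3 (0.33 log units; beyond the scatter). Compound 3 is therefore estimated at 15 nM, within 5 nM to 45 nM.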

Compound 3, half-maximal inhibitory concentration: 261 nM
Estimate against measurement, compound 3: 17-fold (1.24 log units) below, outside the stated range (above it).
By their numbers in this assay, from the lowest: compound 2; then compound 1; then compound 3.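

In this assay, adding a single carbonyl on the amine nitrogen, so that (4-chlorophenyl)amino becomes ((4-chlorophenyl)carbonyl)amino, produces a 37-fold higher number from compound 2 to compound 3 (1.57 log units; beyond the scatter) in a large step. This shows that the position is highly sensitive to what sits on this nitrogen, which the earlier step, where the whole group changed, could not reveal. Nothing available explains the size of this rise. Still open, going by these compounds, is whether a methylene in place of the carbonyl, giving a benzyl amine, or a sulfonyl group on the same nitrogen would keep the number near that of compound 2.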